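Amino for methoxy on a benzimidazole-free core: cytotoxicity outlook

The source may hold more compounds than are shown below. What is called first, only, known or untested is meant among the compounds shown, and "the series" means these compounds.

Compound 1 `COc1ccc(-c2nc3cc(C(F)(F)F)ccc3[nH]2)c(OC)c1` in an ADME assay on Vero cells (Chlorocebus sabaeus) for cytotoxicity (on this read-out lower numbers stand for higher toxicity in this test and higher numbers for lower toxicity in this test), gives > 100000 nM, which is a limit of the assay.
Compound 2 `COc1ccc(-c2nc3cc(C(C)=O)ccc3[nH]2)c(OC)c1` in this assay gives > 100000 nM, again a limit of the assay.

Compound 1 therefore stands only at a limit, and every value shown sits at the limit of > 100000 nM in this assay, at which 2 of the 2 values shown sit. Compound 3 `COc1ccc(-c2nc3cc(C(F)(F)F)ccc3[nH]2)c(N)c1` differs from compound 1 by amino in place of methoxy on an aromatic carbon. Among the measured compounds shown here, the single measured step, a step that the two limits leave unreadable from compound 1 to compound 2, concerns another position and cannot be read, so no measured step bears on this change. Compound 3 is expected to remain near the limit, estimated at 150000 nM (range 40000 nM to 500000 nM), an expected step that the limit leaves unreadable from compound 1 to compound 3.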

Compound 3, half-maximal cytotoxic concentration: 50000 nM
Beside the measured number, compound 3's estimate is 3.0-fold (0.48 log units) above it; the measured number falls inside the stated range.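

In this assay, amino in place of methoxy, ortho to a large group, gives the first read-out among the compounds shown that is a number and not a limit, with an at least 2.0-fold lower number from compound 1 to compound 3 (0.30 log units; that floor lies within the scatter). This position on the core of compound 1 can therefore bring the read-out into the measurable range, though the size of the step is known only as a floor. The other compounds remain at a limit: the limit of > 100000 nM in this assay, at which 2 of the 3 values shown sit.

From the compounds shown here alone, it remains open whether the same change would give a similar result with acetyl in place of trifluoromethyl, as in compound 2. Going by these compounds, it also remains open how a hydroxyl or a dimethylamino group would compare with amino at this position.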